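A phenyl for tert-butyl swap on the shared core

The compounds below may be only part of what the source reports. "The series", "measured", "known", "first", "only" and "open" are said of these compounds alone.

Values in an ADME assay on Caco-2 cells (Homo sapiens) for permeability, read by LC-MS, in the apical to basolateral direction, with a stated time of 60 min, at pH 6.5 (on this read-out lower numbers stand for lower permeability and higher numbers for higher permeability), for the measured compounds follow
Compound 1 `O=C(NCc1cc(Cl)ccc1-n1cnnn1)[C@@H]1[C@@H]2C[C@@H]2CN1C(=O)[C@H](O)Cc1ccccn1` gives 0.62 10^-6 cm/s
Compound 2 `O=C(NCc1cc(Cl)ccc1-n1cnnn1)[C@@H]1[C@H]2C[C@H]2CN1C(=O)[C@H](O)c1ccccc1` gives 12 10^-6 cm/s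
Compound 3 `CC(C)(C)[C@@H](O)C(=O)N1C[C@H]2C[C@H]2[C@H]1C(=O)NCc1cc(Cl)ccc1-n1cnnn1` gives 3.8 10^-6 cm/s

Compound 3 holds the middle place of the three, under compound 2 and over compound 1. Compound 4 `O=C(NCc1cc(Cl)ccc1-n1cnnn1)[C@@H]1[C@@H]2C[C@@H]2CN1C(=O)[C@H](O)c1ccccc1` differs from compound 3 by one change (phenyl in place of tert-butyl on a saturated chain carbon bound to a carbonyl carbon and an oxygen on a saturated carbon). Compound 4 has not yet been measured. Going by the values given here, one measured step touches this place (a 6.1-fold higher number from compound 1 to compound 3 (0.79 log units; beyond the scatter)), but it brought in tert-butyl and involved no phenyl. Compound 2 also carries phenyl there, on a core of different spatial arrangement, so it is only a loose guide to a higher number. A small upward move in this assay is therefore expected, probably within the scatter (a 1.6-fold higher number from compound 3 to compound 4 (0.20 log units; within the scatter)). Compound 4 is estimated at 6 10^-6 cm/s (range 2 10^-6 cm/s to 15 10^-6 cm/s) in this assay when measured.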

Compound 4, apparent permeability: 2.2 10^-6 cm/s
The estimate for compound 4 lay 2.7-fold (0.44 log units) above the measured number; the measured number falls inside the stated range.
By their numbers in this assay, from the lowest: compound 1; then compounds 4 and 3 (each within the scatter of the next); then compound 2.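

In this assay, phenyl in place of tert-butyl at this place stays within the scatter, a 1.7-fold lower number from compound 3 to compound 4 (0.24 log units; within the scatter), so on this core the two groups are not told apart. Phenyl still separates from (pyridin-2-yl)methyl on the same core, a 3.5-fold higher number from compound 1 to compound 4 (0.55 log units; beyond the scatter). With phenyl held fixed, a step beyond the scatter also appears, a 5.5-fold lower number from compound 2 to compound 4 (0.74 log units; beyond the scatter), and it comes with configuration alone: the fact that compounds 2 and 4 differ only in the configuration as drawn

On these data alone, whether tert-butyl and phenyl would also stay within the scatter on the core of compound 2 remains open. So does how an amine or a carboxylic acid at this place would read in this assay.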